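Cytotoxicity of a benzimidazole amide series: compound 4

This account rests on a few compounds, and the source may have more. Where it says the series, first, only, none or still open, it means among the compounds named here.

Measured so far in an ADME assay on Vero cells (Chlorocebus sabaeus) for cytotoxicity, read by resazurin assay, with a stated time of 3 days; on this read-out lower numbers stand for stronger inhibition and higher numbers for weaker inhibition:
Compound 1, `CCN(CC)c1cc2[nH]c(C3CCCCC3)nc2cc1NC(=O)OCCOCCOC`, gives > 100 ug/mL.
Compound 2, `CCN(CC)c1cc2[nH]c(C3CCCCC3)nc2cc1NC(=O)c1ccc(OC(F)(F)F)cc1`, gives > 100 ug/mL.
Compound 3, `CCN(CC)c1cc2[nH]c(C3CCCCC3)nc2cc1NC(=O)c1ccc(F)cc1`, gives > 100 ug/mL.

Each of these three values is a limit of the assay rather than a number. Compound 3 therefore stands at the same limit as the two other compounds, and its steps to them, a step that the two limits leave unreadable from compound 1 to compound 3 and a step that the two limits leave unreadable from compound 2 to compound 3, are unreadable; the same holds for a step that the two limits leave unreadable from compound 1 to compound 2. All that is known is the limit of > 100 ug/mL in this assay, at which 3 of the 3 values shown sit.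

Compound 4, `C=Cc1cccc(C(=O)Nc2cc3nc(C4CCCCC4)[nH]c3cc2N(CC)CC)c1`, differs from compound 3 by 3-vinylphenyl in place of 4-fluorophenyl on a carbonyl carbon. For the measured compounds named here, none of the measured steps gives a readable size, so no direction can be drawn from them; the shared core has simply stayed at the limit through three different groups on the carbonyl carbon, compound 1, compound 2 and compound 3 alike. The step from compound 3 to compound 4 is expected to be a step that the limit leaves unreadable from compound 3 to compound 4, that is, again nothing readable. Compound 4 is therefore expected to give about 150 ug/mL in this assay, with a range of 60 ug/mL to 400 ug/mL, most likely reported once more only as a limit.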

Compound 4, half-maximal inhibitory concentration: > 100 ug/mL
Compound 4: a limit, no number; the forecaster's own chance of this, stated with the estimate: 80%; the middle value is on the limit's open side.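

In this assay compound 4 gives > 100 ug/mL, which is a limit and not a number. Its steps from compound 1, compound 2 and compound 3 cannot be read. The compounds shown leave open at what concentration any of them would become cytotoxic, and whether the group on the carbonyl carbon has any bearing on that: the limit of > 100 ug/mL in this assay, at which 4 of the 4 values shown sit.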